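The compounds below may be only part of what the source reports. "The series", "measured", "known", "first", "only" and "open" are said of these compounds alone.

Within the data shown here, compound 3 `COC(=O)c1ccc(CN(CCCc2c(N)nc(N)nc2O)c2cc(F)c(F)cc2[N+](=O)[O-])cc1` gives 59000 nM in a functional assay on CCRF-CEM cells (Homo sapiens) for cytotoxicity, in the absence of a further agent (a higher number here means a weaker inhibitor, a lower number a stronger inhibitor), the highest of the three numbers so far, though within the scatter of compound 1 `COC(=O)c1ccc(CN(CCCc2c(N)nc(N)nc2O)c2cc(F)ccc2[N+](=O)[O-])cc1` at 45000 nM and of compound 2 `Nc1nc(N)c(CCCN(Cc2ccc(NC(CCC(=O)O)C(=O)O)cc2)c2cc(F)c([N+](=O)[O-])cc2[N+](=O)[O-])c(O)n1` at 40000 nM. Compound 4 `COC(=O)c1ccc(CN(CCCc2c(N)nc(N)nc2O)c2cc(F)c([N+](=O)[O-])cc2[N+](=O)[O-])cc1` differs from compound 3 by nitro in place of fluoro on an aromatic carbon. Among the measured compounds shown here, the one measured step on the same ring, a 1.3-fold higher number from compound 1 to compound 3 (0.12 log units; within the scatter), stayed within the scatter. The same two nitro groups on that ring as in compound 4 are carried by compound 2, which gives 40000 nM. Nothing here points to a step beyond the scatter in either direction. Compound 4 is therefore expected to give 50000 nM in this assay, with a range of 25000 nM to 100000 nM. The expected step is a 1.2-fold lower number from compound 3 to compound 4 (0.07 log units; within the scatter), within the scatter.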

Compound 4, half-maximal inhibitory concentration: 2500 nM
Beside the measured number, compound 4's estimate is 20-fold (1.30 log units) above it; the measured number lies below the stated range.
By their numbers in this assay, from the lowest: compound 4; then compounds 2, 1 and 3 (each within the scatter of the next).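

In this assay, among these compounds, nitro at this position, para to a large group, is the first change to go beyond the scatter: a 24-fold lower number from compound 3 to compound 4 (1.37 log units; beyond the scatter) against fluoro and an 18-fold lower number from compound 1 to compound 4 (1.26 log units; beyond the scatter) against hydrogen, whereas fluoro in place of hydrogen gave only a 1.3-fold higher number from compound 1 to compound 3 (0.12 log units; within the scatter). The two nitro groups alone do not give the low number, as compound 2 also carries them, and methoxycarbonyl in place of (1,3-dicarboxypropyl)amino gives a 16-fold lower number from compound 2 to compound 4 (1.20 log units; beyond the scatter). No evidence is available to explain these steps. Open, from the compounds shown here alone, is whether an amine or a nitrile at this position keeps the low number. Also open, going by these compounds, is how a free carboxylic acid in place of methoxycarbonyl would compare.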